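The source may hold more compounds than are shown below. What is called first, only, known or untested is meant among the compounds shown, and "the series" means these compounds.

Measured so far:

- Compound 1, `CNC(=O)c1ccccc1Oc1nc(Nc2ccccc2F)ncc1Br`, in a functional assay on A549 cells (Homo sapiens) for antiproliferative activity, read by MTT assay, with a stated time of 24 h (a higher number here means a weaker inhibitor, a lower number a stronger inhibitor), compound 1 gives 35500 nM.
- Compound 2, `CNC(=O)c1ccccc1Oc1nc(Nc2ccc(C)cc2C)ncc1Br`, in this assay compound 2 gives 27300 nM.

Both compounds share the same core and differ only in the aryl group carried on the nitrogen attached to the aromatic ring. Among the compounds with values here, compound 2 carries the 2,4-dimethylphenyl group; against compound 1 the only recorded step is a 1.3-fold lower number from compound 1 to compound 2 (0.11 log units; within the scatter), so on these two numbers compound 2 and compound 1 cannot be told apart.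

Compound 3, `CNC(=O)c1ccccc1Oc1nc(Nc2cccc(C(C)C)c2)ncc1Br`, changes the same position once more: 3-isopropylphenyl in place of 2,4-dimethylphenyl on a nitrogen on an aromatic ring. Within the data shown here, the only measured step that bears on this kind of exchange is the one from compound 1 to compound 2, which swapped one substituted phenyl for another on this nitrogen and stayed within the scatter. With nothing else to go on, the exchange for the 3-isopropylphenyl group is expected to bring no step beyond the scatter either, that is a 1.0-fold higher number from compound 2 to compound 3 (0.01 log units; within the scatter).

Compound 3 is therefore estimated to give 28000 nM in this assay, with a plausible range from 12000 nM to 65000 nM.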

Compound 3, half-maximal inhibitory concentration: 7140 nM
Compound 3: middle estimate off by 3.9-fold (0.59 log units), on the high side; measured number below the stated range.
By their numbers in this assay, from the lowest: compound 3; then compounds 2 and 1 (each within the scatter of the next).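

In this assay this nitrogen no longer looks indifferent to the aryl group it carries: the 3-isopropylphenyl group gives a 3.8-fold lower number from compound 2 to compound 3 (0.58 log units; beyond the scatter) and, set against the 2-fluorophenyl group, a 5.0-fold lower number from compound 1 to compound 3 (0.70 log units; beyond the scatter). Within the data shown here, the first pair of compounds showed only a change within the scatter, whereas these steps show that exchanging one carbon-only aromatic group for another at this place can move the number beyond it, making compound 3 the strongest inhibitor of the three. Nothing available here accounts for why the 3-isopropylphenyl group gives the lower number.

This single exchange replaces the 2,4-dimethylphenyl group as a whole, so the compounds shown cannot separate any contribution of the isopropyl group from that of losing the two methyl groups. Also open, on these data alone, is how far the trend runs, for example whether a 3-tert-butylphenyl group would lower the number further, or whether a phenyl ring carrying an amine or a carboxylic acid would keep the activity of compound 3.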